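Amide series: benzyl for tert-butyl, cytotoxicity outlook

The source may report more compounds than this note shows. Statements on the series, on what has been measured and on what is new or still open speak of the compounds shown alone.

Compound 3 `C=CC1=C(C(=O)NC(C)(C)C)C(c2ccc(F)cc2)OC1` gives only a limit in a functional assay on A549 cells (Homo sapiens) for cytotoxicity, read by MTT assay, with a stated time of 24 h (on this read-out lower numbers stand for stronger inhibition and higher numbers for weaker inhibition), namely > 100000 nM. Compound 1 `C=CC1=C(C(=O)O)C(c2ccc(F)cc2)OC1` likewise reports a limit, > 100000 nM. Compound 2 `C=CC1=C(C(=O)Nc2ccccc2OC)C(c2ccc(F)cc2)OC1` also sits at a limit, > 100000 nM. The steps a step that the two limits leave unreadable from compound 1 to compound 3 and a step that the two limits leave unreadable from compound 2 to compound 3 are thus unreadable; all that is known is the limit of > 100000 nM in this assay, at which 3 of the 3 values shown sit. Compound 4 `C=CC1=C(C(=O)NCc2ccccc2)C(c2ccc(F)cc2)OC1` differs from compound 3 by benzyl in place of tert-butyl on an amide-type nitrogen. Among the measured compounds shown here, no measured step bears on this change in a readable way, and nothing among the three compounds points in either direction. Compound 4 is therefore expected to stay at the same limit, with the step of a number no higher from compound 3 to compound 4 (the limit leaves the size open) taken as none beyond the scatter. The estimate for compound 4 is 100000 nM, within 30000 nM to 300000 nM, most likely reported again only as a limit.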

Compound 4, half-maximal inhibitory concentration: > 100000 nM
Compound 4 ended at the assay's limit; the forecaster's own chance of this, stated with the estimate: 85%; the middle value sits exactly at the limit.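

Among the compounds shown here, no step from compound 1, compound 2 or compound 3 to compound 4 can be read, and the only finding is a limit: the limit of > 100000 nM in this assay, at which 4 of the 4 values shown sit. The compounds shown leave open whether any amide-type nitrogen substituent gives a measurable value.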